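Compound 3: Swapping Sulfur for Oxygen Ahead of Measurement

A few compounds are considered here, and "the series" means these few. Any claim that something is new, unique, unknown or untested is made for them only; others in the source may bear on it.

Of the compounds shown here, two built on a shared core have been measured in a functional assay on HeLa cells (Homo sapiens) for antiproliferative activity, with a stated time of 24 h; on this read-out higher numbers stand for weaker inhibition and lower numbers for stronger inhibition. Compound 1 `NC(=O)c1c(NC(=O)c2ccccc2Cl)sc2c1CCN(C(=S)Nc1ccccc1I)C2` gives 29000 nM, and compound 2 `NC(=O)c1c(NC(=O)c2ccccc2Cl)sc2c1CCN(C(=S)Nc1c(Cl)cccc1Cl)C2` gives 26500 nM. Going by the values given here, the single change between them, a 1.1-fold lower number from compound 1 to compound 2 (0.04 log units; within the scatter), leaves the two within the scatter of each other, so compound 2 stands at one of two numbers that cannot be told apart. Compound 3 `NC(=O)c1c(NC(=O)c2ccccc2Cl)sc2c1CCN(C(=O)Nc1c(Cl)cccc1Cl)C2` differs from compound 2 by a group of 11 heavy atoms (7 carbon, 1 nitrogen, 1 oxygen, 2 chlorine; one six-membered aromatic ring of carbon only) in place of a group of 11 heavy atoms (7 carbon, 1 nitrogen, 1 sulfur, 2 chlorine; one six-membered aromatic ring of carbon only), on an amine nitrogen in a ring. Among the compounds with values here, no measured step touches this exchange: the only step known alters the aromatic ring on the nitrogen and keeps the sulfur in place. With nothing in the data to set a direction, compound 3 is expected to show an estimated step of a 1.0-fold higher number from compound 2 to compound 3 (0.01 log units; within the scatter), nothing beyond the scatter. Compound 3 is therefore estimated at 27000 nM in this assay, within a range from 9000 nM to 80000 nM.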

Compound 3, half-maximal inhibitory concentration: 27200 nM
The estimate for compound 3 lay 1.0-fold (0.00 log units) below the measured number; low and high end bracket the measured number.
By their numbers in this assay, from the lowest: compounds 2, 3 and 1 (each within the scatter of the next).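

In this assay, going by these compounds alone, the exchange of sulfur for oxygen that gives (2,6-dichlorophenyl)carbamoyl on the amine nitrogen in a ring amounts to a 1.0-fold higher number from compound 2 to compound 3 (0.01 log units; within the scatter), the first measured change to that atom rather than to the aromatic ring. Changing both the sulfur and the 2-iodophenyl group together amounts to a 1.1-fold lower number from compound 1 to compound 3 (0.03 log units; within the scatter), so among these three compounds neither change, alone or combined, moves the number beyond the scatter. No supporting data bear on why this exchange leaves the result so flat.

All three compounds carry a halogen-substituted phenyl ring on this group, so the compounds shown leave open whether an amine, a carboxylic acid or a longer alkyl chain there would shift the number. Going by these compounds, the primary carboxamide and the 2-chlorobenzoyl group are also the same throughout, so what a change at either would do remains unknown.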